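The source may hold more compounds than are shown below. What is called first, only, known or untested is meant among the compounds shown, and "the series" means these compounds.

Measured so far:
- compound 1, `N#C/C(=C\c1c[nH]c2cc(F)ccc12)C(=O)c1c[nH]c2ccccc12`: 17000 nM
- compound 2, `N#C/C(=C\c1c[nH]c2ccccc12)C(=O)c1c[nH]c2ccccc12`: 16100 nM
- compound 3, `COc1ccc(Cn2cc(/C=C(\C#N)C(=O)c3c[nH]c4cc(F)ccc34)c3ccccc32)cc1`: > 50000 nM

In a functional assay on A549 cells (Homo sapiens) for cytotoxicity, read by WST assay, with a stated time of 24 h (on this read-out lower numbers stand for stronger inhibition and higher numbers for weaker inhibition), compound 1 gives 17000 nM and compound 2 gives 16100 nM; the step of a 1.1-fold lower number from compound 1 to compound 2 (0.02 log units; within the scatter) goes with the change (hydrogen in place of fluoro on an aromatic carbon). For compound 3 this assay returns only a limit, > 50000 nM, which is the limit of > 50000 nM in this assay, at which 1 of the 3 values shown sits. The difference between the core of compound 1 and the core of compound 3 is not broken down here.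

Compound 4, `COc1ccc(Cn2cc(/C=C(\C#N)C(=O)c3c[nH]c4ccccc34)c3ccccc32)cc1`, is not yet measured. It stands to compound 3 as compound 2 stands to compound 1: the change is hydrogen in place of fluoro on an aromatic carbon, and the place reads the same word for word in both pairs, so it is the same change. Since the measured step in this assay is a 1.1-fold lower number from compound 1 to compound 2 (0.02 log units; within the scatter), the expected step that the limit leaves unreadable from compound 3 to compound 4 is of the same size, and compound 4 is therefore expected to sit at 60000 nM, most likely again only as a limit.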

Compound 4, half-maximal inhibitory concentration: > 50000 nM
Compound 4 gave a limit, no number (the forecaster's own chance of this, stated with the estimate: 70%); the middle value is on the limit's open side.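

In this assay compound 4 gives > 50000 nM, which is a limit and not a number, and compound 3 also stands only at a limit: the limit of > 50000 nM in this assay, at which 2 of the 4 values shown sit. The change of 6-fluoro-1H-indol-3-yl to 1H-indol-3-yl therefore cannot be read on the core of compound 3, so the result neither confirms nor contradicts the step on the core of compound 1, a 1.1-fold lower number from compound 1 to compound 2 (0.02 log units; within the scatter). The readable change is 4-methoxybenzyl in place of hydrogen on an aromatic nitrogen, with an at least 3.1-fold higher number from compound 2 to compound 4 (0.49 log units; beyond the scatter).

The compounds shown leave open whether a smaller group on that nitrogen, such as methyl, or a benzyl carrying an amine, would give values below the limit. Only such a value could show whether the fluoro change carries over.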